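Alkoxy variation on the methanesulfonamide acetophenone series

The source may hold more compounds than are shown below. What is called first, only, known or untested is meant among the compounds shown, and "the series" means these compounds.

Measured so far:
compound 1 `CCCCOc1cc(C(C)=O)ccc1NS(C)(=O)=O`, 72.7%
compound 2 `CCCCCOc1cc(C(C)=O)ccc1NS(C)(=O)=O`, 59.6%
compound 3 `CCCCCOc1cc(C(C)=O)ccc1N`, 9.88%

In a functional assay on the whole organism (strain Wistar) for inhibition, with Rattus norvegicus as the target, read by paw edema, with stated times of 30 min and 5 h, at a dose of 100 mg/kg by the oral route (a lower number here means less inhibition, a higher number more inhibition at the dose given (going by the name of the read-out)), compound 2 stands second of the three, below compound 1 by a number 13.1 percentage points lower from compound 1 to compound 2 (beyond the scatter) and above compound 3 by a number 49.7 percentage points lower from compound 2 to compound 3 (beyond the scatter). Compound 4 `CC(=O)c1ccc(NS(C)(=O)=O)c(OC2CCCCC2)c1` differs from compound 2 in one place: cyclohexyl in place of pentyl on an oxygen on an aromatic ring. Among the compounds with values here, only the step from compound 1 to compound 2 bears on this, a modest fall with one more carbon on the chain; no ring replacement has been measured. The change is expected to give a small move in this assay, downward if anything, with a shift of a number 6.6 percentage points lower from compound 2 to compound 4 (within the scatter) from compound 2. For compound 4 the estimate is 53%, within 33% to 70%.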

Compound 4, a percentage reported as inhibition, in the whole organism at one dose (the size of the read-out at that dose, not a potency): 73.7%
Beside the measured number, compound 4's estimate is 20.7 percentage points below it; the whole stated range lies below it.
By their numbers in this assay, from the lowest: compound 3; then compound 2; then compounds 1 and 4 (each within the scatter of the next).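

In this assay the group on the oxygen need not be an open chain: cyclohexyl in place of pentyl gives a number 14.1 percentage points higher from compound 2 to compound 4 (beyond the scatter), and cyclohexyl in place of butyl gives a number 1 percentage points higher from compound 1 to compound 4 (within the scatter). The fall seen with pentyl therefore does not extend to every larger group at this position. Nothing at hand explains why the ring and the chain differ here.

As far as these compounds go, whether cyclopentyl or a branched chain such as isopropyl on the oxygen behaves like cyclohexyl remains open. So does the effect of replacing methylsulfonyl with hydrogen on the nitrogen when cyclohexyloxy is present.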